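Two measured compounds and one change at the amino substituent

The source may hold more compounds than are shown below. What is called first, only, known or untested is meant among the compounds shown, and "the series" means these compounds.

Measured so far:
compound 1 `O=S(=O)(/C=C/c1c(F)c(F)c(F)c(F)c1F)Nc1c(F)c(F)c(F)c(F)c1F` gives 35000 nM
compound 2 `COC(=O)C(C)Nc1cc(NS(=O)(=O)/C=C/c2c(OC)cc(OC)cc2OC)ccc1OC` gives 100 nM

In a functional assay on DU-145 cells (Homo sapiens) for cytotoxicity, read by trypan blue exclusion, with a stated time of 96 h (on this read-out higher numbers stand for weaker inhibition and lower numbers for stronger inhibition), compound 2 holds the lowest of the two numbers recorded, and compound 1 stands far above it, a gap well beyond the scatter of repeated runs. Within the data shown here, no pair of measured compounds differs in a single place, so no measured step exists to lean on.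

Compound 3 `COc1cc(OC)c(/C=C/S(=O)(=O)Nc2ccc(OC)c(NC(C(=O)O)c3ccc(Cl)cc3)c2)c(OC)c1` is the next structure for this assay. It differs from compound 2 as follows: carboxy(4-chlorophenyl)methyl in place of 1-(methoxycarbonyl)ethyl on a nitrogen on an aromatic ring. Among the measured compounds shown here, nothing measured so far touches this position, so the direction of the step rests on expectation alone. Compound 3 is expected to sit a little weaker than compound 2, the estimated step being a 3.0-fold higher number from compound 2 to compound 3 (0.48 log units; beyond the scatter), with wide uncertainty. The estimate for compound 3 is 300 nM, expected to fall between 50 nM and 2000 nM.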

Compound 3, half-maximal inhibitory concentration: 75 nM
The estimate for compound 3 lay 4.0-fold (0.60 log units) above the measured number; low and high end bracket the measured number.
By their numbers in this assay, from the lowest: compounds 3 and 2 (each within the scatter of the next); then compound 1.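

In this assay, among these compounds, the change on a nitrogen on an aromatic ring gives a 1.3-fold lower number from compound 2 to compound 3 (0.12 log units; within the scatter), the first measured step at this position, and the numbers for the two compounds cannot be told apart. The entering carboxy(4-chlorophenyl)methyl has 11 heavy atoms against 6 in the leaving 1-(methoxycarbonyl)ethyl and adds a six-membered aromatic ring and a hydrogen-bond donor, yet this larger group at this position gives a number within the scatter of the smaller one. No supporting data bear on this result.

As far as these compounds go, the step changes the ester to a carboxy group and adds the 4-chlorophenyl ring at once, so the share of each part stays open. A 1-carboxyethyl group or a (methoxycarbonyl)(4-chlorophenyl)methyl group on the same nitrogen would separate the two, and a plain amino group would show what the substituent contributes at all.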